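From thiophen-3-yl to 1-benzofuran-2-yl on the shared core

A few compounds are considered here, and "the series" means these few. Any claim that something is new, unique, unknown or untested is made for them only; others in the source may bear on it.

Compound 1 `Cc1nc(N)c2c(-c3ccco3)cn([C@@H]3O[C@H](CO)[C@@H](O)[C@H]3O)c2n1`: > 20000 nM
Compound 2 `Cc1nc(N)c2c(-c3ccsc3)cn([C@@H]3O[C@H](CO)[C@@H](O)[C@H]3O)c2n1`: > 20000 nM

In a functional assay on K562 cells (Homo sapiens), read by MTT assay, with a stated time of 72 h (a higher number here means a weaker inhibitor, a lower number a stronger inhibitor), compound 2 gives > 20000 nM, which is a limit and not a number. Compound 1 gives > 20000 nM, which is also a limit. Among the measured compounds shown here, the position of the series so far is the limit of > 20000 nM in this assay, at which 2 of the 2 values shown sit.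

The next change leads from compound 2 to compound 3 `Cc1nc(N)c2c(-c3cc4ccccc4o3)cn([C@@H]3O[C@H](CO)[C@@H](O)[C@H]3O)c2n1`: 1-benzofuran-2-yl in place of thiophen-3-yl on an aromatic carbon. For the measured compounds named here, it falls on the same aromatic carbon as the only measured step, a step that the two limits leave unreadable from compound 1 to compound 2. That step offers no size to carry over, and no readable step exists in either direction. Going by the values given here, the entering group has more heavy atoms than the one it replaces, but no measured compound here shows what that does in this assay. The working expectation is therefore that compound 3 stays close to the limit reached by compound 1 and compound 2, though a measurable value cannot be ruled out.

For compound 3 the expected value is 20000 nM. The estimated range for compound 3 is 7000 nM to 40000 nM. The expected step is a number no higher from compound 2 to compound 3 (the limit leaves the size open).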

Compound 3, half-maximal inhibitory concentration: 4990 nM
Compound 3: the middle estimate sits 4.0-fold (0.60 log units) above what was measured; measured number outside the range, below it.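

In this assay, among the compounds shown here, 1-benzofuran-2-yl gives the first readable value at this aromatic carbon of the shared core, with an at least 4.0-fold lower number from compound 2 to compound 3 (0.60 log units; beyond the scatter) on replacing thiophen-3-yl. Replacing furan-2-yl gives an at least 4.0-fold lower number from compound 1 to compound 3 (0.60 log units; beyond the scatter), and this pair differs by the added six-membered aromatic ring of carbon only, so among the compounds shown, that ring accompanies the move away from the limit. The two groups with one five-membered aromatic ring stay at that limit, while the group with the added ring leaves it: the limit of > 20000 nM in this assay, at which 2 of the 3 values shown sit.

Going by these compounds, the step between the two limited compounds cannot be read, and both new steps give only a smallest size, so how far compound 3 truly lies from compound 1 and compound 2 stays open. Also open, on these data alone, is whether phenyl, naphthalen-2-yl or 1-benzothiophen-2-yl on this carbon would give a readable value in this assay, and whether an amine or a carboxylic acid on the 1-benzofuran-2-yl group would move the number in either direction.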